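A few compounds are considered here, and "the series" means these few. Any claim that something is new, unique, unknown or untested is made for them only; others in the source may bear on it.

Three esters of the same fluorinated nucleoside have so far been tested in a functional assay on ZR-75-1 cells (Homo sapiens) for inhibition, read by MTT assay, with a stated time of 24 h; a higher number here means a weaker inhibitor of growth, a lower number a stronger inhibitor of growth. Compound 1 `N[C@@H](CC(=O)OC[C@H]1O[C@@H](n2cc(F)c(=O)[nH]c2=O)C[C@@H]1O)C(=O)O` gives 3900000 nM in this assay. Compound 2 `N[C@@H](CCC(=O)O[C@H]1C[C@H](n2cc(F)c(=O)[nH]c2=O)O[C@@H]1CO)C(=O)O` gives 1600000 nM in this assay, and compound 3 `N[C@@H](CCC(=O)OC[C@H]1O[C@@H](n2cc(F)c(=O)[nH]c2=O)C[C@@H]1O)C(=O)O` gives 1700000 nM in this assay; the numbers for compound 2 and compound 3 fall within the usual scatter of each other, so nothing separates them. Compound 1 and compound 3 differ in one place, (amino(carboxy)methyl in place of 2-amino-2-carboxyethyl on a saturated chain carbon bound to a carbonyl carbon), and this change produces a 2.3-fold higher number from compound 3 to compound 1 (0.36 log units; beyond the scatter).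

Compound 4 `N[C@@H](CC(=O)O[C@H]1C[C@H](n2cc(F)c(=O)[nH]c2=O)O[C@@H]1CO)C(=O)O` is the untested member of the set. It is related to compound 2 by exactly the same change, (amino(carboxy)methyl in place of 2-amino-2-carboxyethyl on a saturated chain carbon bound to a carbonyl carbon), made at the same kind of position described above. The two cores that carry this change, those of compound 2 and compound 3, hold the same atoms joined differently, and that difference between the cores is not broken down here.

For the measured compounds named here, on the strength of the single earlier example, compound 4 is expected to show a step of a 2.3-fold higher number from compound 2 to compound 4 (0.36 log units; beyond the scatter) from compound 2, a step of about the size seen as a 2.3-fold higher number from compound 3 to compound 1 (0.36 log units; beyond the scatter), with the proviso that this rests on one pair only. Compound 4 is therefore estimated at 3700000 nM in this assay, with a plausible range from 1600000 nM to 8500000 nM.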

Compound 4, concentration for 50% growth inhibition: 3100000 nM
Beside the measured number, compound 4's estimate is 1.2-fold (0.08 log units) above it, and the stated range covers the measured number.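

In this assay, the change from 2-amino-2-carboxyethyl to amino(carboxy)methyl on the core of compound 2 gives a 1.9-fold higher number from compound 2 to compound 4 (0.29 log units; within the scatter), a step that on its own cannot be told apart from repeat measurements. Set beside the step on the other core, it runs in the same direction and the two steps do not differ, so within this pair of cores the change carries over with no detectable dependence on the core: the same change on two cores in this assay, a 2.3-fold higher number (0.36 log units; beyond the scatter) from compound 3 to compound 1 and a 1.9-fold higher number (0.29 log units; within the scatter) from compound 2 to compound 4, 1.2-fold (0.07 log units) apart, within the scatter of two such steps This does not amount to a general rule, since it rests on two pairs only, one of whose steps stays within the scatter, and it says nothing about why the number moves or about how the two cores compare with each other when they carry other groups.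

On these data alone, it remains open whether a longer chain than 3-amino-3-carboxypropyl, or a chain ending in an amine alone or in a carboxylic acid alone, would shift the number further on either core. Also open, as far as these compounds go, is how these esters stand against the nucleoside with a free hydroxyl in place of the ester, and whether the same step would appear on a third core.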